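Moving the chlorine on the alkyne-linked phenyl ring

This account rests on a few compounds, and the source may have more. Where it says the series, first, only, none or still open, it means among the compounds named here.

Measured compounds in a functional assay on HEK293 cells for negative allosteric modulation of metabotropic glutamate receptor 5 (Homo sapiens), read by FLIPR and calcium flux; a lower number here means a stronger inhibitor, a higher number a weaker inhibitor:
compound 1 `CN1CCc2nc(C#Cc3ccc(Cl)cc3)ccc2C1=O` — 352 nM
compound 2 `Cc1ccccc1C#Cc1ccc2c(n1)CCN(C(C)C)C2=O` — 810 nM
compound 3 `CC(C)N1CCc2nc(C#Cc3cccc(Cl)c3)ccc2C1=O` — 5.7 nM

Among these three, compound 3 stands lowest in this assay, with compound 1 the nearest and compound 2 the furthest, both beyond the scatter. For the measured compounds named here, the only single-point step available on the aryl group at the triple-bonded carbon is a 140-fold lower number from compound 2 to compound 3 (2.15 log units; beyond the scatter), a large shift that shows how strongly this assay answers to what sits on that ring.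

Compound 4 `CC(C)N1CCc2nc(C#Cc3ccc(Cl)cc3)ccc2C1=O` is compound 3 with 4-chlorophenyl in place of 3-chlorophenyl on a triple-bonded carbon. Going by the values given here, no measured pair isolates this particular change. Compound 1 also carries the 4-chlorophenyl but differs from compound 3 elsewhere as well, so its value and that of compound 3 can only be set side by side: compound 1 gives 352 nM, while compound 3 gives 5.7 nM. Given that the 4-chlorophenyl compound measured so far sits well above compound 3, and that the aryl step already seen was large, compound 4 is expected to land above compound 3 in this assay, an estimated step of an 18-fold higher number from compound 3 to compound 4 (1.24 log units; beyond the scatter). The expected value for compound 4 is 100 nM, with a range from 20 nM to 500 nM.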

Compound 4, half-maximal inhibitory concentration: 4230 nM
Compound 4: middle estimate off by 42-fold (1.63 log units), on the low side; the whole stated range lies below it.
By their numbers in this assay, from the lowest: compound 3; then compound 1; then compound 2; then compound 4.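

In this assay the two groups being exchanged have the same atoms, yet moving the chlorine gives a 740-fold higher number from compound 3 to compound 4 (2.87 log units; beyond the scatter) and thus decides the outcome at this position on the triple-bonded carbon. The 4-chlorophenyl also compares poorly with the 2-methylphenyl, with a 5.2-fold higher number from compound 2 to compound 4 (0.72 log units; beyond the scatter) as the step, so a chlorine on this ring does not by itself give a low number. With the 4-chlorophenyl held fixed, isopropyl in place of methyl on the amide-type nitrogen in a ring gives a 12-fold higher number from compound 1 to compound 4 (1.08 log units; beyond the scatter) as its step, which shows that the isopropyl does not bring a low number with every aryl group. Nothing given here accounts for either of these large steps.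

The compounds shown leave open whether the same change at the nitrogen would move the number in the same direction with the 3-chlorophenyl in place, since no methyl partner of compound 3 appears among them. They also leave open how 2-chlorophenyl, 3-methylphenyl or 3-fluorophenyl would stand on the triple-bonded carbon, and so whether the low number of compound 3 is particular to chlorine.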